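Chloro in place of methoxy on a compound at the limit

This account rests on a few compounds, and the source may have more. Where it says the series, first, only, none or still open, it means among the compounds named here.

Three compounds have been measured in a functional assay on DLD-1 cells (Homo sapiens) for cytotoxicity, read by MTT assay, with a stated time of 48 h; a higher number here means a weaker inhibitor, a lower number a stronger inhibitor:
compound 1, `Nc1nc(-c2ccccc2)cn1/N=C/c1cc2ccccc2nc1Cl`: 16400 nM
compound 2, `Cc1ccc(-c2cn(/N=C/c3cc4ccccc4nc3Cl)c(N)n2)cc1`: a limit, > 50000 nM
compound 3, `COc1ccc(-c2cn(/N=C/c3cc4ccccc4nc3Cl)c(N)n2)cc1`: a limit, > 50000 nM

Among the compounds with values here, compound 1 is the only one with a true number. Compound 2 sits at a limit of the assay. Compound 3 also sits at a limit, so its standing can only be read as weak: it is one of the two values at the limit of > 50000 nM in this assay, at which 2 of the 3 values shown sit. Methyl in place of hydrogen on an aromatic carbon gives an at least 3.0-fold higher number from compound 1 to compound 2 (0.48 log units; beyond the scatter), and methoxy in place of hydrogen on an aromatic carbon gives an at least 3.0-fold higher number from compound 1 to compound 3 (0.48 log units; beyond the scatter). Between the two substituted compounds the size is not readable: a step that the two limits leave unreadable from compound 2 to compound 3.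

Compound 4, `Nc1nc(-c2ccc(Cl)cc2)cn1/N=C/c1cc2ccccc2nc1Cl`, carries the change (chloro in place of methoxy on an aromatic carbon). Within the data shown here, the steps that bear on it are those from compound 1, where a group on that aromatic carbon pushed the value to the limit twice; no measured step separates one such group from another. The expectation for compound 4 is therefore no readable change in this assay, a number no higher from compound 3 to compound 4 (the limit leaves the size open), with the value likely staying at the limit. The estimate for compound 4 is 50000 nM, in the range 12000 nM to 150000 nM.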

Compound 4, half-maximal inhibitory concentration: > 50000 nM
Compound 4 ended at the assay's limit; the forecaster's own chance of this, stated with the estimate: 70%; the middle value lies on the limit itself.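

In this assay, chloro in place of hydrogen on this aromatic carbon gives an at least 3.0-fold higher number from compound 1 to compound 4 (0.48 log units; beyond the scatter). Chloro is a single chlorine atom with no hydrogen-bond acceptor, so the weakening seen with methyl and methoxy now also appears with a third, differently built group, and among the compounds shown every group tried on this carbon goes against compound 1, which has only hydrogen there. The steps among compound 2, compound 3 and compound 4 cannot be read, so methoxy, methyl and chloro cannot be put in any order, as all three compounds stand at a limit and not at a true number: the limit of > 50000 nM in this assay, at which 3 of the 4 values shown sit.

Still open, going by these compounds, is whether any group on this carbon can keep the value of compound 1, 16400 nM, or improve on it; fluoro, hydroxyl or an amine would each put that to the test. Also open, on these data alone, is how much weaker than compound 1 the three substituted compounds really are, since a limit gives no size beyond itself.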